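The compounds below may be only part of what the source reports. "The series", "measured", "known", "first", "only" and "open" are said of these compounds alone.

In a functional assay on L1210 cells (Mus musculus) for cytotoxicity, read by MTT assay, with a stated time of 24 h (a higher number here means a weaker inhibitor, a lower number a stronger inhibitor), compound 1 (`COc1cc(C(=O)/C=C/c2ccc(Cl)cc2)cc(OC)c1OC`) gives 44500 nM and compound 2 (`COc1cc(C(=O)/C=C/c2ccc(F)cc2)cc(OC)c1OC`) gives 46500 nM on the shared core. Going by the values given here, compound 2 therefore stands level with compound 1, the only other measured compound, and fluoro in place of chloro on an aromatic carbon amounts to a 1.0-fold higher number from compound 1 to compound 2 (0.02 log units; within the scatter) in this pair. Compound 3 (`COc1cc(C(=O)/C=C/c2ccc(Cl)cc2Cl)cc(OC)c1OC`) differs from compound 2 by a single change (2,4-dichlorophenyl in place of 4-fluorophenyl on a double-bonded chain carbon bound to a double-bonded chain carbon). Among the compounds with values here, no measured compound carries the 2,4-dichlorophenyl group, so only the step within that pair bears on this change, and it offers no direction. With compound 1 and compound 2 separated by a 1.0-fold higher number from compound 1 to compound 2 (0.02 log units; within the scatter) in this assay, no step beyond the scatter is expected here. The estimated step is a 1.2-fold lower number from compound 2 to compound 3 (0.07 log units; within the scatter) for this change. Compound 3 is accordingly estimated at 40000 nM with an expected range from 17000 nM to 90000 nM in this measurement.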

Compound 3, half-maximal inhibitory concentration: 52500 nM
The estimate for compound 3 lay 1.3-fold (0.12 log units) below the measured number; the measured number falls inside the stated range.
By their numbers in this assay, from the lowest: compounds 1, 2 and 3 (each within the scatter of the next).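

In this assay, 2,4-dichlorophenyl in place of 4-fluorophenyl on a double-bonded chain carbon bound to a double-bonded chain carbon gives a 1.1-fold higher number from compound 2 to compound 3 (0.05 log units; within the scatter), and chloro in place of hydrogen on an aromatic carbon gives a 1.2-fold higher number from compound 1 to compound 3 (0.07 log units; within the scatter). The earlier pair had shown only one halogen exchanged for another on the phenyl group, whereas these steps show that a phenyl group carrying two chloro substituents also stands level with those carrying one halogen. Across these three compounds, neither the identity nor the number of halogens on that group separates the values beyond the scatter.

Going by these compounds, whether a phenyl group bearing an amine or a carboxylic acid in place of halogen would stand apart from these three compounds remains open. No supporting measurement bears on this result.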